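Moving a methyl group on a three-ring pyridine series

This account rests on a few compounds, and the source may have more. Where it says the series, first, only, none or still open, it means among the compounds named here.

Compound 1, `Clc1ccc(-c2cc(-c3ccoc3)cc(-c3cccs3)n2)cc1`, in a functional assay on HeLa cells (Homo sapiens) for cytotoxicity, in the presence of a further agent that is not named here; a lower number here means a stronger inhibitor, a higher number a weaker inhibitor: 5530 nM
Compound 2, `Cc1cccc(-c2cc(-c3ccc(Cl)o3)cc(-c3ccsc3)n2)c1`: 20300 nM
Compound 3, `Clc1ccc(-c2cc(-c3ccco3)cc(-c3cccs3)n2)cc1`: 32700 nM

Compound 2 has the second highest number of the three; its value and that of compound 3 lie within the scatter of each other, while compound 1 sits clearly lower. Compound 4, `Cc1ccccc1-c1cc(-c2ccc(Cl)o2)cc(-c2ccsc2)n1`, differs from compound 2 by 2-methylphenyl in place of 3-methylphenyl on an aromatic carbon. For the measured compounds named here, the only measured step, a 5.9-fold higher number from compound 1 to compound 3 (0.77 log units; beyond the scatter), concerns the furan group, not the methylphenyl group, so nothing measured bears directly on this change. Without such a precedent the expectation is no step beyond the scatter, and compound 4 is expected to give 20000 nM, between 7000 nM and 60000 nM, which means an expected step of a 1.0-fold lower number from compound 2 to compound 4 (0.01 log units; within the scatter).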

Compound 4, half-maximal inhibitory concentration: 9770 nM
For compound 4 the middle estimate is 2.0-fold (0.31 log units) above the measured one; the measured number falls inside the stated range.
By their numbers in this assay, from the lowest: compounds 1 and 4 (each within the scatter of the next); then compounds 2 and 3 (each within the scatter of the next).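

In this assay the methyl group's place on the phenyl ring matters: 2-methylphenyl in place of 3-methylphenyl gives a 2.1-fold lower number from compound 2 to compound 4 (0.32 log units; beyond the scatter) with the atom count unchanged. For the compounds shown here, this is the first measured step at this position, though a modest one, and the earlier furan step said nothing about it. Nothing available explains the difference.

Still open, as far as these compounds go, is how a 4-methylphenyl group, a plain phenyl or an aminophenyl group would fare here. Also open, from the compounds shown here alone, is whether the same methyl shift would matter with other groups on the shared core.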